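The source may hold more compounds than are shown below. What is called first, only, known or untested is meant among the compounds shown, and "the series" means these compounds.

For the measured compounds named here, compound 2 `O=S(=O)(Nc1ccc(-c2nc3ccccc3o2)cc1)c1cccs1` is the only compound in this set with a finite number: in an assay on cells for inhibition of HSP60/HSP10 (Homo sapiens), with a stated time of 60 min (on this read-out higher numbers stand for weaker inhibition and lower numbers for stronger inhibition), compound 2 gives 63000 nM. Compound 1 `O=S(=O)(Nc1ccc(-c2nc3ccccc3o2)cc1)c1ccccc1Cl` is the other member, and in this assay compound 1 gives > 100000 nM, which is a limit of the assay rather than a number. The step of an at least 1.5-fold lower number from compound 1 to compound 2 (0.20 log units; that floor lies within the scatter) is therefore known only as a floor, and the limit of > 100000 nM in this assay, at which 1 of the 2 values shown sits, shows where that floor comes from. Compound 3 `O=S(=O)(Nc1ccc(-c2nc3ccccc3o2)cc1)c1ccccc1O` differs from compound 2 by 2-hydroxyphenyl in place of thiophen-2-yl on a sulfonyl sulfur. Going by the values given here, the single measured step, from compound 1 to compound 2, also exchanges the ring on the sulfonyl sulfur, but its size is no more than a floor lying within the scatter, so it gives no firm direction for a further exchange at the same place. For compound 3 a number close to that of compound 2 is expected, with an expected step of a 1.1-fold lower number from compound 2 to compound 3 (0.02 log units; within the scatter). Compound 3 is estimated at 60000 nM, within a range from 15000 nM to 250000 nM.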

Compound 3, half-maximal inhibitory concentration: > 100000 nM
Compound 3: a limit, no number; the forecaster's own chance of this, stated with the estimate: 35%; at least 1.6-fold (0.22 log units) between middle value and limit.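

In this assay, compound 3 stays at a limit of the assay, so a second six-membered ring on the sulfonyl sulfur, now 2-hydroxyphenyl, gives no number, as 2-chlorophenyl did in compound 1. For the compounds shown here, the change gives an at least 1.5-fold higher number from compound 2 to compound 3 (0.20 log units; that floor lies within the scatter), so it sets no firm order between these two compounds, even though thiophen-2-yl remains the only group at this place with a number. The step from compound 1 to compound 3 cannot be read, and the other steps are only floors, because most of the readings are limits: the limit of > 100000 nM in this assay, at which 2 of the 3 values shown sit.

Going by these compounds, whether a plain phenyl ring, or one carrying an amine or a carboxylic acid, on the sulfonyl sulfur would give a number rather than a limit stays open. Also open, on these data alone, is whether another five-membered aromatic ring, such as furan-2-yl, would give a reading clearly different from that of compound 2, 63000 nM.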